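Hydroxy in Place of Hydrogen: Compound 3 to Compound 4

The source may hold more compounds than are shown below. What is called first, only, known or untested is meant among the compounds shown, and "the series" means these compounds.

Three compounds of the series have numbers in a functional assay on NUGC-3 cells (Homo sapiens) for cytotoxicity, read by sulforhodamine B assay, with a stated time of 72 h; a lower number here means a stronger inhibitor of growth, a higher number a weaker inhibitor of growth. Compound 1 `O=C(Nc1ccccc1C(F)(F)F)C1CCc2ccccc2N1C(=O)c1cccc(Cl)c1` gives 754 nM. Compound 2 `COc1ccc(NC(=O)C2CCc3ccccc3N2)cc1` gives 51900 nM. Compound 3 `O=C(Nc1ccccc1)C1CCc2ccccc2N1` gives 59000 nM, the highest of the three numbers; its nearest neighbour is compound 2, which lies within the scatter of it, while compound 1 sits far below it. Among the measured compounds shown here, compound 1 differs from compound 3 in more than one place, so no single step connects the two, and their values simply stand side by side.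

One measured step exists between single-change neighbours: a 1.1-fold higher number from compound 2 to compound 3 (0.06 log units; within the scatter), hydrogen in place of methoxy on an aromatic carbon. The change from compound 3 to compound 4 `O=C(Nc1ccccc1O)C1CCc2ccccc2N1` is hydroxy in place of hydrogen on an aromatic carbon. For the measured compounds named here, the only step that bears on it is that removal of methoxy between compound 2 and compound 3, which moved nothing beyond the scatter, so the expectation in this assay is a step of similar size, that is, none beyond the scatter, with no settled direction. The value of compound 4 is accordingly estimated at 50000 nM, with a range from 15000 nM to 150000 nM. The expected step is a 1.2-fold lower number from compound 3 to compound 4 (0.07 log units; within the scatter).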

Compound 4, concentration for 50% growth inhibition: 2680 nM
Estimate against measurement, compound 4: 19-fold (1.27 log units) above; measured number outside the range, below it.
By their numbers in this assay, from the lowest: compound 1; then compound 4; then compounds 2 and 3 (each within the scatter of the next).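

In this assay, hydroxy in place of hydrogen on an aromatic carbon, ortho to a large group, gives a 22-fold lower number from compound 3 to compound 4 (1.34 log units; beyond the scatter), so this six-membered aromatic ring of carbon only holds a place where one small substituent moves the number. The earlier step, a 1.1-fold higher number from compound 2 to compound 3 (0.06 log units; within the scatter), showed no such sensitivity, and it concerned methoxy at a different place, so the two steps describe different changes and the flat result does not extend to this one. The entering hydroxy brings 1 heavy atom, 1 hydrogen-bond donor and 1 hydrogen-bond acceptor, but no measurement on hand explains the size of the step.

Open, as far as these compounds go, is whether an amine or a fluorine at this same place, ortho to a large group, gives a step of like size, which would help to show whether the step belongs to hydroxy itself or to substitution at this place in general. Also open, from the compounds shown here alone, is whether hydroxy at this place brings a comparable step in a compound carrying the chlorobenzoyl group of compound 1.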